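This account rests on a few compounds, and the source may have more. Where it says the series, first, only, none or still open, it means among the compounds named here.

Compound 1 `O=S(=O)(NCCCNCc1ccc(Cl)c(Cl)c1)c1cc(C(F)(F)F)cc(C(F)(F)F)c1` carries a 3,4-dichlorophenyl group on the chain of the shared core. For the measured compounds named here, in a functional assay on Capan-2 cells (Homo sapiens) for inhibition, read by MTT assay, with a stated time of 72 h (a higher number here means a weaker inhibitor of growth, a lower number a stronger inhibitor of growth), compound 1 gives 1800 nM, the lowest of the three numbers measured so far. Compound 2 `COc1ccc(CNCCCNS(=O)(=O)c2cc(C(F)(F)F)cc(C(F)(F)F)c2)cc1OC` has a 3,4-dimethoxyphenyl group in the same place, and in this assay compound 2 gives 15000 nM. Compound 3 `O=S(=O)(NCCCNCc1cccc2ccccc12)c1cc(C(F)(F)F)cc(C(F)(F)F)c1` has a naphthalen-1-yl group there, and in this assay compound 3 gives 2700 nM. Between them the measured steps are an 8.3-fold higher number from compound 1 to compound 2 (0.92 log units; beyond the scatter), a 1.5-fold higher number from compound 1 to compound 3 (0.18 log units; within the scatter) and a 5.6-fold lower number from compound 2 to compound 3 (0.74 log units; beyond the scatter).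

Compound 4 `COc1cccc(CNCCCNS(=O)(=O)c2cc(C(F)(F)F)cc(C(F)(F)F)c2)c1` differs from compound 1 in one place: 3-methoxyphenyl in place of 3,4-dichlorophenyl on a saturated chain carbon bound to an amine nitrogen. The measured change that most resembles this one is the move to compound 2, which cost an 8.3-fold higher number from compound 1 to compound 2 (0.92 log units; beyond the scatter); the 3-methoxyphenyl group resembles that 3,4-dimethoxyphenyl group but lacks part of it, so a loss of the same kind, though smaller, is expected. The move to compound 3 stayed within the scatter, a 1.5-fold higher number from compound 1 to compound 3 (0.18 log units; within the scatter), so not every replacement in this place costs much. Compound 4 is therefore expected to show a 3.3-fold higher number from compound 1 to compound 4 (0.52 log units; beyond the scatter), a modest weakening. Compound 4 is estimated at 6000 nM, with a range from 2500 nM to 15000 nM.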

Compound 4, concentration for 50% growth inhibition: 6400 nM
Beside the measured number, compound 4's estimate is 1.1-fold (0.03 log units) below it; the measured number falls inside the stated range.
By their numbers in this assay, from the lowest: compounds 1 and 3 (each within the scatter of the next); then compound 4; then compound 2.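

Taking one methoxy off compound 2 gives a 2.3-fold lower number from compound 2 to compound 4 (0.37 log units; beyond the scatter) in this assay, and this is the first step here that changes a single group on the aromatic ring rather than replacing the whole ring unit. Compound 4 still sits on the weaker side of the other two, with a 3.6-fold higher number from compound 1 to compound 4 (0.55 log units; beyond the scatter) and a 2.4-fold higher number from compound 3 to compound 4 (0.37 log units; beyond the scatter) as the steps that separate it from them, so keeping one methoxy is enough to leave a gap beyond the scatter. Among these four compounds, then, the two that carry methoxy give the two highest numbers, the one with two methoxy groups gives the highest of all, and no compound shown goes against this order.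

As far as these compounds go, it remains open whether the methoxy itself raises the number or whether the chlorines lower it, and a plain phenyl group, a phenyl group with a single chlorine, or a pyridine ring on the same chain carbon would help to separate those two readings. Nothing measured alongside these growth numbers accounts for the differences between these groups.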